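Chain length and leukotriene B4 receptor 1 inhibition

A few compounds are considered here, and "the series" means these few. Any claim that something is new, unique, unknown or untested is made for them only; others in the source may bear on it.

Measured so far:
compound 1, `CCc1cc(C(C)=O)c(O)cc1OCCCCCCC#N`: 103%
compound 2, `C=CCc1cc(C(C)=O)c(O)cc1OCCCC#N`: 47%

In an assay on isolated protein for inhibition of leukotriene B4 receptor 1 (Homo sapiens), tested at 10 uM (on this read-out lower numbers stand for less inhibition and higher numbers for more inhibition at the one concentration tested (going by the name of the read-out)), compound 2 stands lowest of the two numbers; the nearest, compound 1, lies higher by a gap beyond the scatter. Compound 3, `C=CCc1cc(C(C)=O)c(O)cc1OCCCCCCCCC#N`, has not yet been measured. It differs from compound 2 by 5-cyanopentyl in place of cyano on a saturated chain carbon, three bonds along the chain from an oxygen on an aromatic ring. Given that compound 1, which also carries a long chain, gives 103%, a rise beyond the scatter is expected for a number 41 percentage points higher from compound 2 to compound 3 (beyond the scatter). Compound 3 is therefore estimated at 88% in this assay, most likely between 60% and 105%.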

Compound 3, a percentage reported as inhibition, at one concentration (the size of the read-out at that concentration, not a potency): 86%
For compound 3 the middle estimate is 2 percentage points above the measured one, and the stated range covers the measured number.
By their numbers in this assay, from the lowest: compound 2; then compound 3; then compound 1.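

For the compounds shown here, the only comparison here that differs in one place, 5-cyanopentyl in place of cyano, gives in this assay a number 39 percentage points higher from compound 2 to compound 3 (beyond the scatter) with the rest of the molecule unchanged. This position therefore accepts the longer nitrile-ended chain, and the read-out responds to that change alone. Nothing measured here accounts for the rise.

The compounds shown leave open whether a still longer chain or one of intermediate length would give a higher or lower number. They also leave open what an amine or a carboxylic acid at the chain end, in place of the nitrile, would do.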